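Bromo for Isopropyl on the Phenyl Group

The source may report more compounds than this note shows. Statements on the series, on what has been measured and on what is new or still open speak of the compounds shown alone.

Compound 1 `CC(C)c1ccc(-c2nc(SCc3cn(CC(=O)NC(=O)Nc4ccccn4)nn3)nc(Nc3ccccc3)c2C#N)cc1` gives in a functional assay on ECa-109 cells (Homo sapiens) for inhibition, read by MTT assay, with a stated time of 72 h (a lower number here means a stronger inhibitor, a higher number a weaker inhibitor), only a limit, > 64000 nM. Compound 2 `COc1ccc(Nc2nc(SCc3cn(CC(=O)NC(=O)Nc4ccccn4)nn3)nc(-c3ccc(C(C)C)cc3)c2C#N)cc1` gives 5420 nM, and compound 3 `CC(C)c1ccc(Nc2nc(SCc3cn(CC(=O)NC(=O)Nc4ccccn4)nn3)nc(-c3ccc(C(C)C)cc3)c2C#N)cc1` gives 2490 nM. The two steps from compound 1, an at least 11-fold lower number from compound 1 to compound 2 (1.07 log units; beyond the scatter) and an at least 25-fold lower number from compound 1 to compound 3 (1.40 log units; beyond the scatter), rest on the limit of > 64000 nM in this assay, at which 1 of the 3 values shown sits, and are therefore lower bounds. Between the two numbered compounds the step is a 2.2-fold lower number from compound 2 to compound 3 (0.34 log units; beyond the scatter), so compound 3 holds the lowest number of the two numbers shown.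

Compound 4 `CC(C)c1ccc(Nc2nc(SCc3cn(CC(=O)NC(=O)Nc4ccccn4)nn3)nc(-c3ccc(Br)cc3)c2C#N)cc1` differs from compound 3 by bromo in place of isopropyl on an aromatic carbon. None of the three measured steps touches this part of the molecule; they all concern the exchange of hydrogen, methoxy and isopropyl elsewhere. The measured steps thus give no direct guide, and the expected step of a 1.8-fold higher number from compound 3 to compound 4 (0.26 log units; within the scatter) for compound 4 is set as a small weakening that may not exceed the scatter. On that basis compound 4 is estimated at 4500 nM in this assay, within a range from 1500 nM to 14000 nM.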

Compound 4, half-maximal inhibitory concentration: > 64000 nM
Compound 4: a limit, no number (the forecaster's own chance of this, stated with the estimate: 5%); at least 14-fold (1.15 log units) between middle value and limit.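

The 4-isopropylphenyl group, which stays the same in compounds 1 to 3, proves to be no neutral part of the molecule: the change from 4-isopropylphenyl to 4-bromophenyl gives an at least 25-fold higher number from compound 3 to compound 4 (1.40 log units; beyond the scatter). In this assay, as far as these compounds go, compound 4 gives > 64000 nM, which is a limit and not a number, so the true size of the step remains unknown. Read with an at least 25-fold lower number from compound 1 to compound 3 (1.40 log units; beyond the scatter), the result shows that a single change at either of two places in compound 3 is enough to reach the limit: the limit of > 64000 nM in this assay, at which 2 of the 4 values shown sit.

With only isopropyl and bromo shown at this position, it stays open whether the loss comes from removing the isopropyl or from bringing in the bromo. From the compounds shown here alone, how a tert-butyl group, a chloro group or an amine would fare here also stays open.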